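The source may hold more compounds than are shown below. What is called first, only, known or untested is meant among the compounds shown, and "the series" means these compounds.

Measured compounds: compound 1 `CCOC(=O)CCCN(c1ccccc1)[C@H]1c2cc(C#N)ccc2OC(C)(C)[C@@H]1O`, compound 2 `CCOC(=O)CN(c1nc(C)cs1)[C@H]1c2cc(C#N)ccc2OC(C)(C)[C@@H]1O`, compound 3 `CCOC(=O)C(=O)N(c1ccc(F)cc1)[C@H]1c2cc(C#N)ccc2OC(C)(C)[C@@H]1O`.

In a functional assay (aorta) with Rattus norvegicus as the target (on this read-out higher numbers stand for weaker inhibition and lower numbers for stronger inhibition), compound 1 reaches only a limit of the assay, > 30000 nM. In this assay compound 2 gives 84000 nM, and compound 3 gives 43000 nM. Compound 1 thus stands at the limit of > 30000 nM in this assay, at which 1 of the 3 values shown sits, with no number of its own.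

Compound 4 `Cc1cc(CN(c2ccccc2)[C@H]2c3cc(C#N)ccc3OC(C)(C)[C@@H]2O)on1` differs from compound 1 by 3-methyl-1,2-oxazol-5-yl in place of 2-(ethoxycarbonyl)ethyl on a saturated chain carbon bound to a nitrogen on an aromatic ring. Within the data shown here, no measured pair shows a change of this kind, so the size of the step rests on expectation alone. The step expected here is an at least 1.2-fold lower number from compound 1 to compound 4 (0.07 log units; that floor lies within the scatter), which is judged to lie near the scatter, in no clear direction. For compound 4 in this assay the estimate is 25000 nM, with a range from 5000 nM to 100000 nM.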

Compound 4, half-maximal inhibitory concentration: > 30000 nM
Compound 4 gave a limit, no number; the forecaster's own chance of this, stated with the estimate: 40%; middle value at least 1.2-fold (0.07 log units) away from the limit.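

In this assay compound 4 gives only a limit, > 30000 nM. Compound 1 is also a limit, so no step can be read between compound 1 and compound 4: the limit of > 30000 nM in this assay, at which 2 of the 4 values shown sit.

The compounds shown leave open what 3-methyl-1,2-oxazol-5-yl in place of 2-(ethoxycarbonyl)ethyl does to inhibition.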